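The compounds below may be only part of what the source reports. "The series", "measured", "known", "first", "only" and "open" are said of these compounds alone.

Working notes on the series. In a functional assay on WI-38 VA13 cells (Homo sapiens) for cytotoxicity (a lower number here means that less compound is needed, a higher number that more compound is needed for the effect), compound 1 `Cc1ccc(C(=O)Nc2ccc3nc(NC(=O)C4CCCCC4)sc3c2)cc1` gives 5.1 ug/mL, while compound 2 `CCCC(C)C(=O)Nc1ccc2nc(NC(=O)C3CCCCC3)sc2c1` gives 0.14 ug/mL, the lower of the two numbers. Compound 3 `CCC(C)(C)C(=O)Nc1ccc2nc(NC(=O)C3CCCCC3)sc2c1` has not yet been measured. It differs from compound 2 as follows: 1,1-dimethylpropyl in place of 1-methylbutyl on a carbonyl carbon. The two have the same atoms, joined differently, with 1,1-dimethylpropyl in place of 1-methylbutyl on a carbonyl carbon. Among the compounds with values here, only one measured step bears on this change: a 36-fold lower number from compound 1 to compound 2 (1.56 log units; beyond the scatter), where 1-methylbutyl replaced 4-methylphenyl at that same place. Within the data shown here, that large step involved leaving a ring behind, whereas here one chain without a ring replaces another, and no measured step compares two such chains. The step expected in this assay is therefore small, none beyond the scatter: a 1.4-fold higher number from compound 2 to compound 3 (0.15 log units; within the scatter). Compound 3 is estimated at 0.2 ug/mL, with an expected range of 0.06 ug/mL to 1 ug/mL.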

Compound 3, half-maximal effective concentration: 1 ug/mL
For compound 3 the middle estimate is 5.0-fold (0.70 log units) below the measured one, and the stated range covers the measured number.
By their numbers in this assay, from the lowest: compound 2; then compound 3; then compound 1.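

In this assay this place on the carbonyl carbon responds to more than the loss of a ring: the change from 1-methylbutyl to 1,1-dimethylpropyl gives a 7.1-fold higher number from compound 2 to compound 3 (0.85 log units; beyond the scatter) even though both chains have the same atoms and neither has a ring. The arrangement of the chain therefore matters here, while replacing 4-methylphenyl with 1,1-dimethylpropyl still gives a 5.1-fold lower number from compound 1 to compound 3 (0.71 log units; beyond the scatter) so that both ring-free chains shown stay lower than the ring-bearing group, by different margins. Nothing available accounts for the gap between the two chains.

Still open, from the compounds shown here alone, is how a straight pentyl chain, a shorter isopropyl group, or a chain carrying an amine or a carboxylic acid would read at this place. Going by these compounds, whether the gap between the two chains persists with a different group on the other amide of the shared core also remains open.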